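Changing the Side Group of Compound 1

The source may hold more compounds than are shown below. What is called first, only, known or untested is meant among the compounds shown, and "the series" means these compounds.

For the measured compounds named here, in a functional assay on LoVo cells (Homo sapiens) for inhibition, read by MTT assay, with a stated time of 48 h (on this read-out lower numbers stand for stronger inhibition and higher numbers for weaker inhibition), compound 1 `COc1ccc(N(C)c2nc(C)nc3ccccc23)cc1OCCC[Se]C#N` gives 921 nM, the lower of the two numbers measured so far, and compound 2 `COc1ccc(N(C)c2nc(C)nc3ccccc23)cc1OCCCCCC[Se]C#N` gives 8580 nM. Compound 3 `COc1ccc(N(C)c2nc(C)nc3ccccc23)cc1C(=O)NCC[Se]C#N` differs from compound 1 at the same side group: a group of 8 heavy atoms (4 carbon, 2 nitrogen, 1 oxygen, 1 selenium; no ring) in place of a group of 7 heavy atoms (4 carbon, 1 nitrogen, 1 oxygen, 1 selenium; no ring), on an aromatic carbon, on an aromatic carbon, ortho to a methoxy group. Going by the values given here, the only measured step, a 9.3-fold higher number from compound 1 to compound 2 (0.97 log units; beyond the scatter), lies beyond the scatter and bears on this change only indirectly, so a smaller rise in the number is expected. The estimated step is a 2.0-fold higher number from compound 1 to compound 3 (0.29 log units; within the scatter). Compound 3 is expected at 1800 nM, within a range of 500 nM to 6500 nM.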

Compound 3, half-maximal inhibitory concentration: 561 nM
For compound 3 the middle estimate is 3.2-fold (0.51 log units) above the measured one, within the range that was stated.
By their numbers in this assay, from the lowest: compounds 3 and 1 (each within the scatter of the next); then compound 2.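

At this aromatic carbon, a side group carrying a carbonyl and an amide hydrogen takes the place of the ether-linked chain with no clear effect: in this assay the change gives a 1.6-fold lower number from compound 1 to compound 3 (0.22 log units; within the scatter), so compound 1 and compound 3 cannot be told apart. The same side group stands well clear of the long chain of compound 2, with a 15-fold lower number from compound 2 to compound 3 (1.18 log units; beyond the scatter). Nothing given here accounts for either step. On these data alone, whether a longer chain on the amide nitrogen would raise the number as the longer ether-linked chain did remains open. So does the outcome with a simple amine in place of the amide.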